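Exchanging the bicyclic amide heteroaryl once more in compound 4

The source may hold more compounds than are shown below. What is called first, only, known or untested is meant among the compounds shown, and "the series" means these compounds.

Three amides sharing one core have been tested in a functional assay on A2780 cells (Homo sapiens) for inhibition, read by sulforhodamine B assay, with a stated time of 72 h; a lower number here means a stronger inhibitor, a higher number a weaker inhibitor. Compound 1 `O=C(NCc1ccc(S(=O)(=O)N2CCCCC2)cc1)c1cnc2nccn2c1` gives 130 nM, compound 2 `O=C(NCc1ccc(S(=O)(=O)N2CCCCC2)cc1)c1cc2ccncc2o1` gives 29 nM, and compound 3 `O=C(NCc1ccc(S(=O)(=O)N2CCCCC2)cc1)c1cc2cnccc2o1` gives 1500 nM. Compound 3 therefore stands highest of the three, with a 12-fold higher number from compound 1 to compound 3 (1.06 log units; beyond the scatter) and a 52-fold higher number from compound 2 to compound 3 (1.71 log units; beyond the scatter), so every exchange of the bicyclic group on the carbonyl carbon moved the number beyond the scatter.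

Compound 4 `O=C(NCc1ccc(S(=O)(=O)N2CCCCC2)cc1)c1ccn2ccnc2c1` differs from compound 3 in this way: a group of 9 heavy atoms (7 carbon, 2 nitrogen; one five-membered aromatic ring with 2 hetero atoms, one six-membered aromatic ring with 1 hetero atom) in place of a group of 9 heavy atoms (7 carbon, 1 nitrogen, 1 oxygen; one five-membered aromatic ring with 1 hetero atom, one six-membered aromatic ring with 1 hetero atom), on a carbonyl carbon. For the measured compounds named here, the steps that bear on it are the earlier exchanges at the same carbonyl carbon, namely a 12-fold higher number from compound 1 to compound 3 (1.06 log units; beyond the scatter) and a 52-fold higher number from compound 2 to compound 3 (1.71 log units; beyond the scatter), both large, and a 4.5-fold lower number from compound 1 to compound 2 (0.65 log units; beyond the scatter), modest. Because compound 3 sits at 1500 nM while the two other bicyclic groups sit far lower, a large downward step is expected for compound 4, roughly back to the level of compound 1, with a 10-fold lower number from compound 3 to compound 4 (1.00 log units; beyond the scatter) as the expected size. Compound 4 is thus estimated at 150 nM in this assay, with a range from 40 nM to 600 nM.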

Compound 4, half-maximal inhibitory concentration: > 10000 nM
Compound 4: a limit, no number (the forecaster's own chance of this, stated with the estimate: 3%); at least 66-fold (1.82 log units) between middle value and limit.
By their numbers in this assay, from the lowest: compound 2; then compound 1; then compound 3. At a limit, above all of these: compound 4.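

In this assay compound 4 ends at a limit of the assay and not at a number: the limit of > 10000 nM in this assay, at which 1 of the 4 values shown sits. At this carbonyl carbon, a bicyclic group with the same heavy-atom total, hydrogen-bond counts and net charge as the group it replaces still gives an at least 6.6-fold higher number from compound 3 to compound 4 (0.82 log units; beyond the scatter), while the wider gaps are an at least 340-fold higher number from compound 2 to compound 4 (2.53 log units; beyond the scatter) and an at least 76-fold higher number from compound 1 to compound 4 (1.88 log units; beyond the scatter). The group of compound 1 also carries a five-membered aromatic ring with 2 hetero atoms, so that ring alone does not fix the number here, and the set now runs from the low value of compound 2 to a limit.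

From the compounds shown here alone, how far compound 4 lies past its limit stays open. So does whether a single phenyl ring at this carbonyl carbon, or an amine added to the entering group, would bring a measurable number back.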